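The source may hold more compounds than are shown below. What is called first, only, known or untested is meant among the compounds shown, and "the series" means these compounds.

Compound 1 `c1csc(-c2ccccc2NCC2=NCCN2)c1` and compound 2 `CCO/N=C(\C)c1ccccc1NCC1=NCCN1` share the same core and differ only in one substituent on an aromatic carbon. In a functional assay for activation of Alpha-1B adrenergic receptor (Homo sapiens), read by calcium flux (on this read-out lower numbers stand for an effect already at smaller amounts and higher numbers for an effect only at larger amounts of compound), compound 1 gives 5.75 nM. For compound 2 this assay reports only a limit, < 5020 nM, and not a number. Compound 2 therefore sits at the limit of < 5020 nM in this assay, at which 1 of the 2 values shown sits, and the step that the limit leaves unreadable from compound 1 to compound 2 cannot be sized from the numbers shown. Compound 3 `CC/C(=N/OC)c1ccccc1NCC1=NCCN1` is built from the same atoms as compound 2, joined differently: a group of 6 heavy atoms (4 carbon, 1 nitrogen, 1 oxygen; no ring) in place of a group of 6 heavy atoms (4 carbon, 1 nitrogen, 1 oxygen; no ring), on an aromatic carbon. For the measured compounds named here, no measured step bears on this rearrangement, and the only measured step in the set is unreadable, so the expectation for compound 3 rests on the limit of compound 2 alone. The step that the limit leaves unreadable from compound 2 to compound 3 is expected to stay within the usual scatter. Compound 3 is therefore estimated at 2500 nM, with a range from 500 nM to 10000 nM, and a fair chance that only a limit is reported.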

Compound 3, half-maximal effective concentration: < 5020 nM
Compound 3 was reported as a limit; the forecaster's own chance of this, stated with the estimate: 50%; the middle value does not contradict the limit.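

Compound 2 and compound 3 are each reported in this assay only as a limit, not a number, so no new step involving compound 3 can be read: the limit of < 5020 nM in this assay, at which 2 of the 3 values shown sit.

The compounds shown leave open how compound 3 truly compares with compound 2 and with compound 1.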